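A few compounds are considered here, and "the series" means these few. Any claim that something is new, unique, unknown or untested is made for them only; others in the source may bear on it.

Compound 1, `COc1cc(-c2nn(-c3ccc(NC(=O)c4cc(Cl)cc(Cl)c4)cc3)cc2-c2ccncc2)ccc1Cl`, was tested in a functional assay on A375P cells (Homo sapiens) for antiproliferative activity, read by MTT assay, with a stated time of 48 h; on this read-out higher numbers stand for weaker inhibition and lower numbers for stronger inhibition; its result, > 20000 nM, is a limit of the assay rather than a number. Compound 2, `O=C(Nc1ccc(-n2cc(-c3ccncc3)c(-c3ccc(Cl)c(O)c3)n2)cc1)Nc1cccc(Cl)c1Cl`, gives 16800 nM. Compound 3, `O=C(Nc1ccc(-n2cc(-c3ccncc3)c(-c3ccc(Cl)c(O)c3)n2)cc1)c1ccc(Cl)c(Cl)c1`, gives 6700 nM.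

Compound 3 therefore stands with the lowest of the two numbers shown, and the remaining result belongs to compound 1, which sits at the limit of > 20000 nM in this assay, at which 1 of the 3 values shown sits. Among the compounds with values here, the only measured step between neighbours is a 2.5-fold lower number from compound 2 to compound 3 (0.40 log units; beyond the scatter), a modest change that came from replacing the amino-linked dichlorophenyl with a directly attached one.

Compound 4, `O=C(Nc1ccc(-n2cc(-c3ccncc3)c(-c3ccc(Cl)c(O)c3)n2)cc1)c1cc(Cl)cc(Cl)c1`, differs from compound 3 only in where the two chlorines sit: 3,5-dichlorophenyl in place of 3,4-dichlorophenyl on a carbonyl carbon. Within the data shown here, no measured step moves a chlorine around this ring, so the one step that exists does not bear directly on it; it only shows that changes at this end of the molecule have so far shifted the number modestly. The expectation for compound 4 is a step of a 1.0-fold higher number from compound 3 to compound 4 (0.02 log units; within the scatter), within the scatter. Compound 4 is estimated at 7000 nM, between 3000 nM and 16000 nM.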

Compound 4, half-maximal inhibitory concentration: 6800 nM
Compound 4: the middle estimate sits 1.0-fold (0.01 log units) above what was measured, and the stated range covers the measured number.
By their numbers in this assay, from the lowest: compounds 3 and 4 (each within the scatter of the next); then compound 2. At a limit, above all of these: compound 1.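

Moving the chlorines from 3,4-dichlorophenyl to 3,5-dichlorophenyl on a carbonyl carbon makes no real difference in this assay (a 1.0-fold higher number from compound 3 to compound 4 (0.01 log units; within the scatter)), so these two chlorine patterns cannot be told apart by this read-out. Compared with the (2,3-dichlorophenyl)amino group on the carbonyl carbon, the 3,5-dichlorophenyl group also gives a lower number (a 2.5-fold lower number from compound 2 to compound 4 (0.39 log units; beyond the scatter)), matching what the 3,4-dichlorophenyl group of compound 3 showed. Within the data shown here, the first reading for hydrogen in place of methyl on an oxygen on an aromatic ring (an at least 2.9-fold lower number from compound 1 to compound 4 (0.46 log units; beyond the scatter)) starts from a limit and not a number: the limit of > 20000 nM in this assay, at which 1 of the 4 values shown sits.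

Still open is whether this ring needs its chlorines at all, since the compounds shown include no unsubstituted phenyl or monochlorophenyl ring there. Also open, as far as these compounds go, is how a different group on this ring, such as trifluoromethyl or an amine, would read.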